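The source may hold more compounds than are shown below. What is called first, only, known or untested is meant among the compounds shown, and "the series" means these compounds.

Measured compounds:
Compound 1 `COc1ccc(/C=C/C(=O)c2sc(Nc3ccc(Cl)cc3)nc2C)cc1` gives > 25000 nM in a functional assay on NCI-H460 cells (Homo sapiens) for cytotoxicity, read by MTT assay (a lower number here means a stronger inhibitor, a higher number a weaker inhibitor), which is a limit of the assay.
Compound 2 `Cc1cccc(Nc2nc(C)c(C(=O)/C=C/c3ccccc3Cl)s2)c1` gives > 25000 nM in this assay, again a limit and not a number.
Compound 3 `Cc1ccc(Nc2nc(C)c(C(=O)/C=C/c3ccc(Cl)cc3)s2)cc1` gives > 25000 nM in this assay, also a limit.

Compound 2 thus stands only at the limit of > 25000 nM in this assay, at which 3 of the 3 values shown sit, with no numeric value to place it against the other two. Compound 4 `Cc1cccc(Nc2nc(C)c(C(=O)/C=C/c3ccccc3)s2)c1` differs from it by hydrogen in place of chloro on an aromatic carbon. For the measured compounds named here, no measured pair shows this change, so the size of the step from compound 2 to compound 4 is unknown; none beyond the scatter is expected, with the result most likely remaining a limit. Compound 4 is estimated at 40000 nM, in the range 10000 nM to 160000 nM, an expected step that the limit leaves unreadable from compound 2 to compound 4.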

Compound 4, half-maximal inhibitory concentration: 21800 nM
Compound 4: middle estimate off by 1.8-fold (0.26 log units), on the high side, and the stated range covers the measured number.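

In this assay, the unsubstituted phenyl of compound 4 gives the only numeric reading among the compounds shown, so this position can now be placed on a scale. The change from 2-chlorophenyl to phenyl gives an at least 1.1-fold lower number from compound 2 to compound 4 (0.05 log units; that floor lies within the scatter), so no real gain from losing the chloro can be claimed. The other compounds offer no number for comparison: the limit of > 25000 nM in this assay, at which 3 of the 4 values shown sit.

Going by these compounds, whether losing the chloro from compound 3 would also give a number remains open. So does the effect of an amine or a carboxylic acid on this aromatic carbon.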